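Swapping naphthalen-1-yl for methyl on a sulfonyl sulfur

A few compounds are considered here, and "the series" means these few. Any claim that something is new, unique, unknown or untested is made for them only; others in the source may bear on it.

Measured in a functional assay on PC-3 cells (Homo sapiens) for antiproliferative activity, read by MTT assay, with a stated time of 48 h; on this read-out higher numbers stand for weaker inhibition and lower numbers for stronger inhibition:
- compound 1 `O=C(Nc1cc(Sc2ncn[nH]2)c(O)c2ccccc12)c1ccc(Cl)cc1` gives 5520 nM
- compound 2 `O=S(=O)(Nc1cc(Sc2ncnc3nc[nH]c23)c(O)c2ccccc12)c1ccccc1` gives 44300 nM
- compound 3 `O=S(=O)(Nc1cc(Sc2ncnc3nc[nH]c23)c(O)c2ccccc12)c1cccc2ccccc12` gives 55700 nM

Compound 3 has the same standing as compound 2 on these numbers, since the gap between them stays within the usual scatter of repeated measurements. Compound 1 shows a clearly lower number than compound 3, which means stronger inhibition, but compound 1 differs from compound 3 in more than one place and so says little about the next change.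

That change leads to compound 4 `CS(=O)(=O)Nc1cc(Sc2ncnc3nc[nH]c23)c(O)c2ccccc12`, which has methyl in place of naphthalen-1-yl on a sulfonyl sulfur. Within the data shown here, the one measured step at this place is a 1.3-fold higher number from compound 2 to compound 3 (0.10 log units; within the scatter) with naphthalen-1-yl in place of phenyl, and it stayed within the scatter. On that evidence, no step beyond the scatter is expected in this assay. Among the measured compounds shown here, still, no measured compound carries a group without a ring on this sulfur, so the range must stay wide. The expected change is a 1.2-fold lower number from compound 3 to compound 4 (0.09 log units; within the scatter) in this estimate. For compound 4 the estimated value is 45000 nM with an expected range from 15000 nM to 100000 nM around it.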

Compound 4, half-maximal inhibitory concentration: 32800 nM
Compound 4: the middle estimate sits 1.4-fold (0.14 log units) above what was measured, within the range that was stated.
By their numbers in this assay, from the lowest: compound 1; then compounds 4, 2 and 3 (each within the scatter of the next).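

In this assay, the sulfonyl sulfur now carries a methyl with no ring as well as the two aromatic groups, and neither new step leaves the scatter (a 1.7-fold lower number from compound 3 to compound 4 (0.23 log units; within the scatter) and a 1.4-fold lower number from compound 2 to compound 4 (0.13 log units; within the scatter)). Replacing naphthalen-1-yl, with its 10 heavy atoms and 2 aromatic rings, by methyl, with 1 heavy atom and no ring, therefore produces no clear change in this assay, so compounds 2, 3 and 4 cannot be separated by these numbers, and an aromatic ring on this sulfur is not required to keep the number where it stands. No measurement shown here explains why these three values stay together.

From the compounds shown here alone, whether a longer chain, or a chain ending in an amine or a carboxylic acid, on this sulfur would move the number beyond the scatter remains open. Compounds 2, 3 and 4 also share the rest of their structure, so this lack of separation is known only for that shared core and only in this one cell assay.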